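From an aryl ester to a nitro group on the shared core

The compounds below may be only part of what the source reports. "The series", "measured", "known", "first", "only" and "open" are said of these compounds alone.

Compound 3 `COc1ccccc1C(=O)O[C@@H]1CO[C@H]2[C@@H]1OC[C@@H]2OC(=O)c1ccccc1OC(C)=O` gives 0.0578 h in an ADME assay on a cell-free system (plasma, Homo sapiens) for metabolic stability, with Plasma (Rattus norvegicus) as the target, read by HPLC, at pH 7.4 (on this read-out higher numbers stand for a longer-lived compound and lower numbers for a shorter-lived compound), the second highest of three numbers; compound 2 `CC(=O)Oc1ccccc1C(=O)O[C@H]1CO[C@H]2[C@@H]1OC[C@H]2OC(=O)c1cccc(C)c1` gives 0.165 h and compound 1 `CC(=O)Oc1ccccc1C(=O)O[C@H]1CO[C@H]2[C@@H]1OC[C@H]2OC(=O)c1cccc(O)c1` gives 0.0183 h. Compound 4 `CC(=O)Oc1ccccc1C(=O)O[C@H]1CO[C@H]2[C@@H]1OC[C@H]2O[N+](=O)[O-]` differs from compound 3 by nitro in place of (2-methoxyphenyl)carbonyl on an oxygen on a saturated carbon. The measured steps all alter the group on a carbonyl carbon: a 9.0-fold higher number from compound 1 to compound 2 (0.96 log units; beyond the scatter), a 3.2-fold higher number from compound 1 to compound 3 (0.50 log units; beyond the scatter) and a 2.9-fold lower number from compound 2 to compound 3 (0.46 log units; beyond the scatter). Among the compounds with values here, none of them replaces that whole group with nitro, so no step bears directly on compound 4; they show only that changes at this place move the read-out by modest amounts. Compound 4 is therefore expected to stay near the measured range, with a 1.7-fold higher number from compound 3 to compound 4 (0.24 log units; within the scatter) as the estimated step. For compound 4 the estimate is 0.1 h, expected to fall between 0.03 h and 0.4 h.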

Compound 4, half-life: 0.0144 h
Compound 4: the middle estimate sits 6.9-fold (0.84 log units) above what was measured; measured number below the stated range.
By their numbers in this assay, from the lowest: compounds 4 and 1 (each within the scatter of the next); then compound 3; then compound 2.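

In this assay, the nitro group on an oxygen on a saturated carbon gives a 4.0-fold lower number from compound 3 to compound 4 (0.60 log units; beyond the scatter) and an 11-fold lower number from compound 2 to compound 4 (1.06 log units; beyond the scatter), whereas a 1.3-fold lower number from compound 1 to compound 4 (0.10 log units; within the scatter) stays within the scatter. The earlier steps shown here only exchanged one aryl carbonyl group for another, while these show that a group without a ring can read level with the (3-hydroxyphenyl)carbonyl group but not with the other two. Nothing given here accounts for these differences. On these data alone, it remains open whether an amine, a carboxylic acid or a longer chain on that oxygen would read like compound 4 or like compound 2.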